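The compounds below may be only part of what the source reports. "The series", "measured", "known", "first", "only" and "open" are said of these compounds alone.

For the measured compounds named here, compound 1, `Cc1cccc(Nc2nc(-c3ccncc3)c(C)s2)c1`, is the only member of this set with a single number in a functional assay on RCC4 cells (Homo sapiens) for inhibition, read by XTT assay, with a stated time of 4 days; a higher number here means a weaker inhibitor, a lower number a stronger inhibitor: compound 1 gives 10000 nM, and its two further entries in this assay carry no number. Two other compounds frame the range seen so far. Compound 2, `Cc1cccc(Nc2nc(-c3ccnc(-c4cncnc4)c3)cs2)c1`, gives 26400 nM; 26900 nM (2 entries) in this assay, and the closeness of its repeats is shown by the several entries of compound 2 in this assay, 26400 nM; 26900 nM (2 entries). Compound 3, `Cc1cccc(Nc2nc(-c3ccncc3C#CCN3CCN(C)CC3)cs2)c1`, gives 2600 nM; 2630 nM (2 entries) in this assay, again with agreeing repeats, (the several entries of compound 3 in this assay, 2600 nM; 2630 nM (2 entries)). On the numbers shown, compound 1 sits between these two, weaker than compound 3 and stronger than compound 2. Going by the values given here, no pair among the three differs in a single place, so no measured step is available to guide the next move.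

Compound 4, `Cc1cccc(Nc2nc(-c3ccncc3)c(CN3CCCCC3)s2)c1`, is not yet measured in this assay. Its difference from compound 1 is piperidin-1-yl in place of hydrogen on a saturated chain carbon bound to an aromatic carbon. Whether such an addition helps cannot be read from the measured compounds; none of them carries this group, and compound 3, the most potent of the three, differs from compound 1 in more than one place. Compound 4 is therefore expected to land near compound 1, with a step of a 1.7-fold lower number from compound 1 to compound 4 (0.22 log units; within the scatter) that is expected to be at most a modest gain, close to the scatter. The estimate for compound 4 in this assay is 6000 nM, with a range from 1500 nM to 25000 nM.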

Compound 4, half-maximal inhibitory concentration: 13200 nM
Compound 4: middle estimate off by 2.2-fold (0.34 log units), on the low side; the measured number falls inside the stated range.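

In this assay the change from methyl to (piperidin-1-yl)methyl, with piperidin-1-yl in place of hydrogen on a saturated chain carbon bound to an aromatic carbon, gives a single readable step (a 1.3-fold higher number from compound 1 to compound 4 (0.12 log units; within the scatter)), and that step lies within the scatter. The earlier compounds shown here offered no step at all, so compound 1 alone could not show whether this place would take anything larger than methyl; compound 4 shows that it takes a six-membered non-aromatic ring on the chain carbon with neither gain nor loss in this read-out. The change therefore leaves the number where it was, and the repeats recorded for other compounds offer nothing on why this addition leaves it unmoved.

On these data alone, it remains open whether a smaller amine such as dimethylamino, or morpholin-4-yl in place of piperidin-1-yl, would also leave the number unmoved at this place. A longer chain between the ring and the core, or a carboxylic acid on the chain, might yet move it beyond the scatter in either direction.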